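From fluoro to (3-fluorobenzyl)oxy: the step to compound 3

A few compounds are considered here, and "the series" means these few. Any claim that something is new, unique, unknown or untested is made for them only; others in the source may bear on it.

- compound 1 `C=CC(=O)Nc1cc2c(Nc3ccc(OCc4cccc(F)c4)c(Cl)c3)ncnc2cc1OCc1cn(CCCCC(=O)NO)nn1`: 14500 nM
- compound 2 `C=CC(=O)Nc1cc2c(Nc3ccc(F)c(Cl)c3)ncnc2cc1OCc1cn(CCC(=O)NO)nn1`: 4450 nM

In a functional assay on NCI-H1975 cells (Homo sapiens) for antiproliferative activity, read by MTT assay, with a stated time of 72 h (on this read-out higher numbers stand for weaker inhibition and lower numbers for stronger inhibition), compound 2 gives 4450 nM, the lower of the two numbers, and the gap to compound 1 lies beyond the scatter. Among the compounds with values here, these two compounds differ in more than one place, so no measured step isolates a single change.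

Compound 3 `C=CC(=O)Nc1cc2c(Nc3ccc(OCc4cccc(F)c4)c(Cl)c3)ncnc2cc1OCc1cn(CCC(=O)NO)nn1` keeps the chain of compound 2 but has (3-fluorobenzyl)oxy in place of fluoro on an aromatic carbon. That group also occurs in compound 1, which gives 14500 nM, so somewhat weaker inhibition is expected in this assay. The expected step of a 1.6-fold higher number from compound 2 to compound 3 (0.20 log units; within the scatter) is small, about the size of the scatter. For compound 3 the estimate is 7000 nM, with an expected range of 2500 nM to 20000 nM.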

Compound 3, half-maximal inhibitory concentration: 21000 nM
Estimate against measurement, compound 3: 3.0-fold (0.48 log units) below; measured number outside the range, above it.
By their numbers in this assay, from the lowest: compound 2; then compounds 1 and 3 (each within the scatter of the next).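

In this assay, (3-fluorobenzyl)oxy in place of fluoro on an aromatic carbon, ortho to a chloro group, gives a 4.7-fold higher number from compound 2 to compound 3 (0.67 log units; beyond the scatter). Within the data shown here, this is the first single change at this position, and it shows that the larger group weakens inhibition by a modest step beyond the scatter. With that group kept, hydroxycarbamoyl in place of 2-(hydroxycarbamoyl)ethyl on a saturated chain carbon gives a 1.4-fold higher number from compound 1 to compound 3 (0.16 log units; within the scatter), so this chain change does not separate the two compounds, and nothing here measured explains either step.

The compounds shown leave open whether the step follows from the benzyl ring itself or from the fluorine on it, which a plain benzyloxy group could address. From the compounds shown here alone, it also remains open how a small methoxy group or an amine would read at this position.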